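Adding a Nitro Group to Compound 1: What to Expect

The source may report more compounds than this note shows. Statements on the series, on what has been measured and on what is new or still open speak of the compounds shown alone.

Measured so far in a functional assay on B16-F10 cells (Mus musculus) for antiproliferative activity, read by ELISA and MTT assay, with a stated time of 48 h; on this read-out lower numbers stand for stronger inhibition and higher numbers for weaker inhibition: compound 1 `O=C(/C=C/c1ccccc1)NS(=O)(=O)c1ccccc1` gives 3.5 ug/mL; compound 2 `O=C(/C=C/c1ccccc1)NS(=O)(=O)c1ccc(F)cc1` gives 2.1 ug/mL.

Compound 1 has the highest of the two numbers; its nearest neighbour is compound 2, and the step of a 1.7-fold lower number from compound 1 to compound 2 (0.22 log units; within the scatter) stays within the scatter. Compound 3 `O=C(/C=C/c1ccc([N+](=O)[O-])cc1)NS(=O)(=O)c1ccccc1` differs from compound 1 by nitro in place of hydrogen on an aromatic carbon. Going by the values given here, no measured step puts a group on that ring; the one step known, from compound 1 to compound 2, changed the other ring and stayed within the scatter. So compound 3 is expected to move about a 1.2-fold lower number from compound 1 to compound 3 (0.07 log units; within the scatter), not beyond the scatter. Compound 3 is estimated at 3 ug/mL, between 1.2 ug/mL and 8 ug/mL.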

Compound 3, half-maximal inhibitory concentration: 4.8 ug/mL
Compound 3: the middle estimate sits 1.6-fold (0.20 log units) below what was measured; the range from low to high includes it.
By their numbers in this assay, from the lowest: compounds 2, 1 and 3 (each within the scatter of the next, the first and the last beyond it).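

Going by these compounds alone, on the ring that carries no sulfonyl group, the only measured change so far puts nitro on an aromatic carbon, para to a large group. In this assay this gives a 1.4-fold higher number from compound 1 to compound 3 (0.14 log units; within the scatter), so this one replacement at this position shows no change that can be told apart from ordinary assay variation. Nothing available explains this outcome.

From the compounds shown here alone, whether an amine or a carboxylic acid at the same place would move the number beyond the scatter remains open. So does the result of nitro on the other ring.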